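From hydroxy to methoxy on compound 2

A few compounds are considered here, and "the series" means these few. Any claim that something is new, unique, unknown or untested is made for them only; others in the source may bear on it.

Of the compounds shown here, two have values so far. In a functional assay on A549 cells (Homo sapiens) for antiproliferative activity, read by sulforhodamine B assay, with a stated time of 48 h (a lower number here means a stronger inhibitor, a higher number a weaker inhibitor), compound 1 (`COc1cccc(/C=C/C(=O)C(=Cc2ccc(OC)c(OC)c2OC)C(=O)/C=C/c2cccc(OC)c2OC)c1OC`) gives 260 nM and compound 2 (`COc1ccc(OC)c(/C=C/C(=O)C(=Cc2ccc(O)c(OC)c2)C(=O)/C=C/c2cc(OC)ccc2OC)c1`) gives 190 nM. These two numbers lie within the usual scatter of each other, so compound 2 stands level with compound 1 on the present data. Going by the values given here, with only this pair measured, no trend can be drawn.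

The next compound, compound 3 (`COc1ccc(OC)c(/C=C/C(=O)C(=Cc2ccc(OC)c(OC)c2)C(=O)/C=C/c2cc(OC)ccc2OC)c1`), differs from compound 2 by methyl in place of hydrogen on an oxygen on an aromatic ring. This places methyl in place of hydrogen on an oxygen on an aromatic ring, turning hydroxy to methoxy, or 4-hydroxy-3-methoxyphenyl to 3,4-dimethoxyphenyl. Among the compounds with values here, the series holds no measured example of this change, so its size in this assay cannot be read from a direct precedent. The working assumption starts from compound 2 at 190 nM and expects no shift beyond the scatter, in either direction. Within the data shown here, the expected change is a 1.1-fold higher number from compound 2 to compound 3 (0.04 log units; within the scatter), and the range is kept wide because no such step has been measured. For compound 3 the estimated value is 210 nM, with an expected range from 80 nM to 520 nM.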

Compound 3, half-maximal inhibitory concentration: 400 nM
Compound 3: middle estimate off by 1.9-fold (0.28 log units), on the low side; measured number inside the range.
By their numbers in this assay, from the lowest: compounds 2, 1 and 3 (each within the scatter of the next, the first and the last beyond it).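

In this assay, going by these compounds alone, replacing the hydrogen on the oxygen of 4-hydroxy-3-methoxyphenyl with methyl gives a 2.1-fold higher number from compound 2 to compound 3 (0.32 log units; beyond the scatter), the first measured step and a modest one. This position therefore responds to the change: within this one pair, the hydroxy goes with the lower number, and the 3,4-dimethoxyphenyl compound loses some activity. The pair shows the size and direction of the step but not its origin, and no measurement among the data shown bears on the cause.

One pair cannot separate the loss of the hydroxy hydrogen from the arrival of the methyl, and an ethoxy, a fluorine or an amine in the same place would help tell these two readings apart. Going by these compounds, it also remains open whether the same step would appear with a different pattern of methoxy groups on the other aromatic rings of the shared core, since this hydroxy to methoxy change has so far been read on a single background.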